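Chalcone triazole series: pentyl analogue in the cell assay

The source may report more compounds than this note shows. Statements on the series, on what has been measured and on what is new or still open speak of the compounds shown alone.

Measured compounds:
compound 1 `COc1cc(/C=C/C(=O)c2cccc(-n3cc(-c4ccc(F)cc4)nn3)c2)ccc1O` — 6450 nM
compound 2 `COc1ccc(-c2cn(-c3cccc(C(=O)/C=C/c4ccc(O)c(OC)c4)c3)nn2)cc1` — 7900 nM

In a functional assay on RAW264.7 cells (Mus musculus) for inhibition, with a stated time of 4 days (on this read-out lower numbers stand for stronger inhibition and higher numbers for weaker inhibition), compound 1 gives 6450 nM and compound 2 gives 7900 nM. Among the measured compounds shown here, the only measured step, a 1.2-fold higher number from compound 1 to compound 2 (0.09 log units; within the scatter), is within the scatter, so compound 2 does not stand apart from compound 1. Compound 3 `CCCCCc1ccc(-c2cn(-c3cccc(C(=O)/C=C/c4ccc(O)c(OC)c4)c3)nn2)cc1` differs from compound 2 by pentyl in place of methoxy on an aromatic carbon. For the measured compounds named here, no measured step exchanges methoxy for pentyl; the fluoro-to-methoxy step is the only one bearing on it, and it was within the scatter. A step beyond the scatter in this assay is therefore not expected. Compound 3 is expected to give 7000 nM (range 2500 nM to 20000 nM), estimated as a 1.1-fold lower number from compound 2 to compound 3 (0.05 log units; within the scatter).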

Compound 3, half-maximal inhibitory concentration: 5780 nM
Estimate against measurement, compound 3: 1.2-fold (0.08 log units) above; the measured number falls inside the stated range.
By their numbers in this assay, from the lowest: compounds 3, 1 and 2 (each within the scatter of the next).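

In this assay, the change from 4-methoxyphenyl to 4-pentylphenyl gives a 1.4-fold lower number from compound 2 to compound 3 (0.14 log units; within the scatter), and pentyl in place of fluoro gives a 1.1-fold lower number from compound 1 to compound 3 (0.05 log units; within the scatter). The position, para to a large group, therefore accepts pentyl without a step beyond the scatter, which extends the fluoro and methoxy comparison to a group with more heavy atoms and no hydrogen-bond acceptor. No supporting evidence bears on this result.

On these data alone, whether an amine, a carboxylic acid or a longer chain here would give a step beyond the scatter remains open. These compounds therefore do not show whether this position can change the number in this assay.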